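The compounds below may be only part of what the source reports. "The series", "measured", "known", "first", "only" and "open" are said of these compounds alone.

Measured so far in a functional assay on HEK293 cells for activation of melanin-concentrating hormone receptor 1 (Rattus norvegicus), read by inositol phosphate accumulation; on this read-out lower numbers stand for an effect already at smaller amounts and higher numbers for an effect only at larger amounts of compound:
- compound 1 `O=C(CCc1ccc(C(F)(F)F)cc1)Nc1ccc2nc(N3CCC3)ccc2c1`: 56 nM
- compound 2 `CN(c1ccc2cc(NC(=O)CCc3ccc(C(F)(F)F)cc3)ccc2n1)C1CCCC1`: 350 nM

Going by the values given here, compound 2 gives the highest number of the two; the only neighbour is compound 1, and the single measured step, a 6.3-fold higher number from compound 1 to compound 2 (0.80 log units; beyond the scatter), lies beyond the scatter.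

Compound 3 `Nc1ccc2cc(NC(=O)CCc3ccc(C(F)(F)F)cc3)ccc2n1` differs from compound 2 in one place: amino in place of cyclopentyl(methyl)amino on an aromatic carbon. The change removes the five-membered non-aromatic ring and the methyl from the exocyclic nitrogen, leaving an amino group that carries a hydrogen-bond donor.

Among the compounds with values here, the one step that bears on this is a 6.3-fold higher number from compound 1 to compound 2 (0.80 log units; beyond the scatter), where the larger cyclopentyl(methyl)amino in place of azetidin-1-yl brought a higher number. Compound 3 goes the other way, to a smaller group, so a lower number than compound 2 is expected; whether an open amino matches a small ring is not shown by any pair here, so the expected step is kept moderate, a 2.9-fold lower number from compound 2 to compound 3 (0.46 log units; beyond the scatter).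

Estimate for compound 3 in this assay: 120 nM, with a range of 35 nM to 400 nM.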

Compound 3, half-maximal effective concentration: 720 nM
Estimate against measurement, compound 3: 6.0-fold (0.78 log units) below; measured number above the stated range.
By their numbers in this assay, from the lowest: compound 1; then compound 2; then compound 3.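

In this assay, moving to a smaller group at this position, next to the ring nitrogen, does not by itself lower the number: amino raises it against cyclopentyl(methyl)amino (a 2.1-fold higher number from compound 2 to compound 3 (0.31 log units; beyond the scatter)) and further against azetidin-1-yl (a 13-fold higher number from compound 1 to compound 3 (1.11 log units; beyond the scatter)). Across the three compounds the number therefore does not follow group size, as azetidin-1-yl gives the lowest number, while both the larger cyclopentyl(methyl)amino and the smaller amino stand higher. No measured evidence here explains this order.

Amino differs from cyclopentyl(methyl)amino in both its ring and its hydrogen-bond donor, and these compounds do not separate the two. Open too, from the compounds shown here alone, is where methylamino, dimethylamino or pyrrolidin-1-yl would fall relative to azetidin-1-yl.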